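From an Aminomethyl to a Formamidine on a Fused Core

A few compounds are considered here, and "the series" means these few. Any claim that something is new, unique, unknown or untested is made for them only; others in the source may bear on it.

Of the compounds shown here, three sharing one fused core have been measured in a functional assay on the whole organism with Rattus norvegicus as the target, at a dose of 40 mg/kg by the intraperitoneal route; on this read-out higher numbers stand for more inhibition at the one dose given (going by the name of the read-out) and lower numbers for less inhibition. Compound 1, `Cc1nc2c(OCc3ccccc3F)cccn2c1N`, gives 93%. Compound 2, `Cc1nc2c(OCc3ccc(C(F)(F)F)cc3)cccn2c1N`, gives 78%. Compound 3, `Cc1nc2c(OCc3ccccc3)cccn2c1CN`, gives 46%, the lowest of the three numbers; its nearest neighbour is compound 2, whose number lies higher by a margin beyond the usual scatter, and compound 1 lies further still, also beyond the scatter. Among the compounds with values here, no single-change step between measured compounds is available, so the effect of any one alteration cannot be read off directly.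

Compound 4, `Cc1nc2c(OCc3ccccc3)cccn2c1/N=C/N(C)C`, is not yet measured. It differs from compound 3 in one place: a group of 5 heavy atoms (3 carbon, 2 nitrogen; no ring) in place of a group of 2 heavy atoms (1 carbon, 1 nitrogen; no ring), on an aromatic carbon. The aminomethyl of compound 3 leaves, and a larger group with no hydrogen-bond donor enters on the same aromatic carbon of the five-membered ring.

Nothing measured shows how this assay responds to such a change. Compounds 1 and 2 give higher numbers than compound 3 but differ from it in more than one place, so no pattern can be claimed. A modest rise, within a wide uncertainty, is expected: the estimated step is a number 9 percentage points higher from compound 3 to compound 4 (within the scatter). Compound 4 is expected to give 55%, with a range from 25% to 85%.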

Compound 4, a percentage reported as inhibition, in the whole organism at one dose (the size of the read-out at that dose, not a potency): 64%
Estimate against measurement, compound 4: 9 percentage points below, and the stated range covers the measured number.
By their numbers in this assay, from the lowest: compound 3; then compound 4; then compound 2; then compound 1.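

In this assay, within the data shown here, the swap of the aminomethyl for the larger group on the aromatic carbon of the five-membered ring gives the first single-change step: a number 18 percentage points higher from compound 3 to compound 4 (beyond the scatter). This shows that the read-out responds to what stands at this position, and that in this pair, losing the hydrogen-bond donor of the aminomethyl does not lower the number. The change also alters the size of the group and adds a double bond outside the aromatic rings, and nothing measured here explains the rise or shows which of these differences matters.

Among these compounds, with only one step at this position, it remains open how other groups on this carbon would compare with the rest of compound 3 kept unchanged, among them a simple amine, a dimethylaminomethyl group or an acetamide. A dimethylaminomethyl group would be especially informative, since it has no hydrogen-bond donor and no double bond outside the aromatic rings, so it could help separate those two changes.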